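Swapping Methoxy for Dimethylamino on the Shared Core

The compounds below may be only part of what the source reports. "The series", "measured", "known", "first", "only" and "open" are said of these compounds alone.

Within the data shown here, compound 1 `COc1ccc(C2CC(c3ccccc3)=NN2C2=NC(=O)/C(=C3\C(=O)Nc4ccccc43)S2)cc1` gives 1810 nM in a functional assay on cells (Cancer cell lines, Homo sapiens) for cytotoxicity, read by sulforhodamine B assay, with a stated time of 48 h (on this read-out higher numbers stand for weaker inhibition of growth and lower numbers for stronger inhibition of growth), the highest of the three numbers measured so far. Compound 2 `COc1ccc(C2CC(c3ccccc3)=NN2C2=NC(=O)/C(=C3\C(=O)Nc4ccc(Br)cc43)S2)cc1` gives 190 nM in this assay, a step of a 9.5-fold lower number from compound 1 to compound 2 (0.98 log units; beyond the scatter). Compound 3 `COc1ccc(C2CC(c3ccc4ccccc4c3)=NN2C2=NC(=O)/C(=C3\C(=O)Nc4ccccc43)S2)cc1` gives 1680 nM in this assay, a step of a 1.1-fold lower number from compound 1 to compound 3 (0.03 log units; within the scatter). Compound 4 `CN(C)c1ccc(C2CC(c3ccccc3)=NN2C2=NC(=O)/C(=C3\C(=O)Nc4ccccc43)S2)cc1` differs from compound 1 by dimethylamino in place of methoxy on an aromatic carbon. Among the measured compounds shown here, neither measured step alters the methoxy group; both change other parts of the structure, so no measured step bears directly on this change, and no step beyond the scatter is expected. Compound 4 is therefore expected to give 1800 nM in this assay, within a range of 700 nM to 4600 nM, which means an expected step of a 1.0-fold lower number from compound 1 to compound 4 (0.00 log units; within the scatter).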

Compound 4, concentration for 50% growth inhibition: 2550 nM
The estimate for compound 4 lay 1.4-fold (0.15 log units) below the measured number; low and high end bracket the measured number.
By their numbers in this assay, from the lowest: compound 2; then compounds 3, 1 and 4 (each within the scatter of the next).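

Dimethylamino in place of methoxy is the first change shown at this aromatic carbon, and it gives a 1.4-fold higher number from compound 1 to compound 4 (0.15 log units; within the scatter) in this assay. The two groups cannot be told apart in this read-out, so this position carries either one on the shared core without a step beyond the scatter. Nothing measured here offers an explanation for this result. On these data alone, whether a hydroxyl, a carboxylic acid or a longer alkoxy chain on this carbon would give a step beyond the scatter remains open. So does whether dimethylamino would read the same with the bromo of compound 2 in place.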